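The compounds below may be only part of what the source reports. "The series", "measured", "known", "first", "only" and "open" are said of these compounds alone.

Measured compounds:
- compound 1, `COc1ccc(-c2ccc3c(NCCCNCc4cccc(OC)c4O)ccnc3c2)cc1`: 9.47
- compound 2, `CC(C)CCc1ccc2c(NCCCNCc3ccco3)ccnc2c1`: 9.47
- compound 3, `COc1ccc(-c2ccc3c(NCCCNCc4ccco4)ccnc3c2)cc1`: 9.47

All three values come from a physicochemical assay for acid dissociation. Compound 1 stands level with compounds 2 and 3 at the digits shown, within the usual scatter of this assay; no ordering among them can be read from these numbers. Two steps have been measured. From compound 1 to compound 3 no change at the digits printed from compound 1 to compound 3 (within the scatter), where furan-2-yl replaces 2-hydroxy-3-methoxyphenyl on a saturated chain carbon bound to an amine nitrogen. From compound 2 to compound 3 no change at the digits printed from compound 2 to compound 3 (within the scatter), where 4-methoxyphenyl replaces isopentyl on an aromatic carbon.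

Compound 4, `COc1cccc(CNCCCNc2ccnc3cc(Oc4ccc(F)cc4)ccc23)c1O`, has not yet been measured. Relative to compound 1 the change is 4-fluorophenoxy in place of 4-methoxyphenyl on an aromatic carbon. The step from compound 2 to compound 3 bears most directly on this, since it also swaps the group on that aromatic carbon of the shared core, and it produced no change beyond the scatter. On that basis the step from compound 1 to compound 4 is expected to be no change at the digits printed from compound 1 to compound 4 (within the scatter), that is, no change beyond the scatter. Compound 4 is therefore estimated at 9.47, with a range from 9.15 to 9.8.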

Compound 4, acid dissociation constant: 9.28
Beside the measured number, compound 4's estimate is 0.19 log units above it; low and high end bracket the measured number.
By their numbers in this assay, from the lowest: compounds 4, 1, 2 and 3 (each within the scatter of the next).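

In this assay, putting 4-fluorophenoxy in place of 4-methoxyphenyl on this aromatic carbon of the shared core gives a number 0.19 log units lower from compound 1 to compound 4 (within the scatter), so the swap cannot be told apart from repeat-measurement noise. The earlier step at this position exchanged isopentyl for 4-methoxyphenyl with furan-2-yl on the chain, whereas this one exchanges two ring-bearing groups of equal heavy-atom count with 2-hydroxy-3-methoxyphenyl on the chain, and neither step goes beyond the scatter. No measurement shown here offers an explanation for the small difference in the printed digits.

The change from 4-methoxyphenyl to 4-fluorophenoxy alters two things at once, the link to the core and the group at the far end of the ring, so a 4-fluorophenyl or a 4-methoxyphenoxy group would be needed to read each alone. On these data alone, it also remains open whether a quite different group at this position, such as an amine or a carboxylic acid, would shift the number beyond the scatter.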